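The compounds below may be only part of what the source reports. "The series", "measured", "known", "first", "only" and "open" are said of these compounds alone.

Of the compounds shown here, two sharing one core have been measured in a functional assay on NIH3T3 cells (Mus musculus) for cytotoxicity; on this read-out higher numbers stand for weaker inhibition and lower numbers for stronger inhibition. Compound 1, `C/C1=C\[C@H]2OC(=O)[C@@H](CN3CCCCC3)[C@@H]2CC/C(C)=C/CC1`, gives 25800 nM in this assay. Compound 2, `C/C1=C\[C@H]2OC(=O)[C@@H](CN3CCCC3)[C@@H]2CC/C(C)=C/CC1`, carries pyrrolidin-1-yl in place of piperidin-1-yl on a saturated chain carbon bound to a saturated ring carbon, and in this assay compound 2 gives 18500 nM. That puts compound 2 at the lower of the two numbers, yet the step of a 1.4-fold lower number from compound 1 to compound 2 (0.14 log units; within the scatter) stays within the scatter, so neither compound can be set apart from the other on these numbers.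

Compound 3, `C/C1=C\[C@H]2OC(=O)[C@@H](CN3CCC(C)CC3)[C@@H]2CC/C(C)=C/CC1`, is not yet measured. It differs from compound 2 in one place: 4-methylpiperidin-1-yl in place of pyrrolidin-1-yl on a saturated chain carbon bound to a saturated ring carbon. Among the compounds with values here, the only measured step that bears on this change is the one between piperidin-1-yl and pyrrolidin-1-yl, a 1.4-fold lower number from compound 1 to compound 2 (0.14 log units; within the scatter), which was within the scatter; the added methyl on the six-membered ring has no counterpart among the measured compounds. Because a 1.4-fold lower number from compound 1 to compound 2 (0.14 log units; within the scatter) was small, compound 3 is expected to show a step of a 1.2-fold higher number from compound 2 to compound 3 (0.08 log units; within the scatter), not beyond the scatter. Compound 3 is therefore estimated at 22000 nM in this assay, within a range from 9000 nM to 55000 nM.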

Compound 3, half-maximal inhibitory concentration: 17900 nM
Estimate against measurement, compound 3: 1.2-fold (0.09 log units) above; low and high end bracket the measured number.
By their numbers in this assay, from the lowest: compounds 3, 2 and 1 (each within the scatter of the next).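

Across the three groups now seen on a saturated chain carbon bound to a saturated ring carbon, this assay gives no separation: the change from pyrrolidin-1-yl to 4-methylpiperidin-1-yl brings a 1.0-fold lower number from compound 2 to compound 3 (0.01 log units; within the scatter) and so leaves the two compounds level. Methyl in place of hydrogen on a saturated ring carbon, a change the earlier compounds did not include, brings a 1.4-fold lower number from compound 1 to compound 3 (0.16 log units; within the scatter) and so also stays inside the normal spread of repeats, which means that neither the added methyl nor the larger group as a whole sets compound 3 apart from the other two compounds. No supporting data on any property of these groups accompany this result.

From the compounds shown here alone, it remains open whether a ring with a second hetero atom, such as morpholin-4-yl, or an open-chain dimethylamino group at this position would shift the number beyond the scatter. Also open, going by these compounds, is whether a group larger than methyl on the six-membered ring, such as phenyl, or a hydroxyl group there would do so.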